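Cyano for acetyl at the cytotoxicity limit

This account rests on a few compounds, and the source may have more. Where it says the series, first, only, none or still open, it means among the compounds named here.

In an ADME assay on 2209-23 cells (Homo sapiens) for cytotoxicity, read by WST assay and thymidine incorporation (a higher number here means that more compound is tolerated, a lower number that less compound is tolerated), compound 1 (`CC(=O)C1=C(C2=C(O)[C@H](C(C)(C)C)N(Cc3ccc(F)cc3)C2=O)Nc2ccc(NS(C)(=O)=O)cc2S1(=O)=O`) gives > 50000 nM as a limit of the assay and not a number. Compound 2 (`COc1cc(CN2C(=O)C(C3=CS(=O)(=O)c4cc(NS(C)(=O)=O)ccc4N3)=C(O)[C@@H]2C(C)(C)C)ccc1F`) gives > 50000 nM as a limit too. Compound 1 therefore stands only at a limit, and the evidence so far goes no further (the limit of > 50000 nM in this assay, at which 2 of the 2 values shown sit). Compound 3 (`CC(C)(C)[C@H]1C(O)=C(C2=C(C#N)S(=O)(=O)c3cc(NS(C)(=O)=O)ccc3N2)C(=O)N1Cc1ccc(F)cc1`) carries cyano in place of acetyl on a double-bonded ring carbon. Among the compounds with values here, no measured step informs this change, so no shift beyond the scatter is expected in this assay (a number no higher from compound 1 to compound 3 (the limit leaves the size open)). Compound 3 is estimated at 50000 nM (expected range 20000 nM to 100000 nM) and may also be reported only as a limit.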

Compound 3, half-maximal cytotoxic concentration: > 50000 nM
Compound 3: only a limit was reported (the forecaster's own chance of this, stated with the estimate: 80%); the middle value sits exactly at the limit.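

No step can be read between compound 1 and compound 3, as both stand only at a limit: the limit of > 50000 nM in this assay, at which 3 of the 3 values shown sit. The compounds shown leave open whether cyano and acetyl differ at all in this assay, and at what concentration any of them turns cytotoxic.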